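Chalcone series: benzyloxy ketone, methoxyphenyl replacing chlorophenyl

This account rests on a few compounds, and the source may have more. Where it says the series, first, only, none or still open, it means among the compounds named here.

Two members of the series have numbers in a functional assay on HCT-116 cells (Homo sapiens) for antiproliferative activity, read by sulforhodamine B assay, with a stated time of 3 days, tested at 25 uM (on this read-out lower numbers stand for a weaker effect and higher numbers for a stronger effect at the one concentration tested), so far. Compound 1 `O=C(/C=C/c1ccccc1Cl)c1ccc(OCc2ccccc2)cc1` gives 54.5% in this assay. Compound 2 `O=C(/C=C/c1cccc([N+](=O)[O-])c1)c1ccccc1` gives 100% in this assay, which puts compound 1 as the lower of the two values, with a gap beyond the usual scatter. Within the data shown here, no step between measured compounds that differ in a single place is available, so the effect of any one change is not yet known from the measured pairs.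

Compound 3 `COc1ccc(/C=C/C(=O)c2ccc(OCc3ccccc3)cc2)cc1` is the next candidate. Its change from compound 1 is 4-methoxyphenyl in place of 2-chlorophenyl on a double-bonded chain carbon bound to a double-bonded chain carbon. Among the measured compounds shown here, with no measured single-place step to lean on, the expected step of a number 9.5 percentage points lower from compound 1 to compound 3 (within the scatter) is small, either no change beyond the scatter or a modest drop. Compound 3 is therefore estimated at 45% in this assay, with a range from 20% to 75%.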

Compound 3, a percentage reported as inhibition, at one concentration (the size of the read-out at that concentration, not a potency): 9.5%
Beside the measured number, compound 3's estimate is 35.5 percentage points above it; the whole stated range lies above it.
By their numbers in this assay, from the lowest: compound 3; then compound 1; then compound 2.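

In this assay, the group on a double-bonded chain carbon bound to a double-bonded chain carbon proves able to set the size of the read-out: with the rest of the core of compound 1 held constant, 4-methoxyphenyl in place of 2-chlorophenyl gives a number 45 percentage points lower from compound 1 to compound 3 (beyond the scatter). Among these compounds, this is the first single-place step, and it shows that this position does not tolerate every substituted phenyl equally at the one concentration tested. Nothing available bears on why the read-out falls with this change.

This single pair changes both the substituent and its place on the phenyl ring, so the contribution of each remains unresolved. 2-Methoxyphenyl and 4-chlorophenyl on the same core would separate the two, while a 4-aminophenyl group would show how far the trend extends beyond these substituents.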